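The source may report more compounds than this note shows. Statements on the series, on what has been measured and on what is new or still open speak of the compounds shown alone.

Working notes on the series. Compound 1 `COc1cc(-c2cc(/C=C/C(=O)c3ccc(N)cc3)[nH]n2)cc(OC)c1OC` is the weaker of the two measured entries in a functional assay on OVCAR-8 cells (Homo sapiens) for cytotoxicity, read by sulforhodamine B assay, with a stated time of 48 h, tested at 0.1 uM (on this read-out higher numbers stand for a weaker effect at the one concentration tested and lower numbers for a stronger effect), where compound 1 gives 98%. Compound 2 `COc1ccc(-c2cc(/C=C/C(=O)c3ccc(OC)c(OC)c3)[nH]n2)cc1` lies close to it; in this assay compound 2 gives 89%, a gap within the usual scatter, so no order between the two is claimed. Compound 3 `COc1cc(-c2cc(/C=C/C(=O)c3ccc(Cl)c(Cl)c3)[nH]n2)cc(OC)c1OC` is not yet measured. Relative to compound 1 the change is 3,4-dichlorophenyl in place of 4-aminophenyl on a carbonyl carbon. Within the data shown here, no measured step of this kind exists, so the expected step from compound 1 to compound 3 is a number 6 percentage points lower from compound 1 to compound 3 (within the scatter), not beyond the scatter. The expected value of compound 3 in this assay is 92%, between 72% and 105%.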

Compound 3, a percentage reported as activity, at one concentration (the size of the read-out at that concentration, not a potency): 97%
Beside the measured number, compound 3's estimate is 5 percentage points below it; the range from low to high includes it.
By their numbers in this assay, from the lowest: compounds 2, 3 and 1 (each within the scatter of the next).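

In this assay, among these compounds, 3,4-dichlorophenyl in place of 4-aminophenyl on a carbonyl carbon gives a number 1 percentage points lower from compound 1 to compound 3 (within the scatter) and is the first step read at this position. This exchange of the aromatic group, with its hydrogen-bond donor and acceptor counts going to none, therefore leaves no difference that can be read at this single concentration. No measured evidence bears on this result.

From the compounds shown here alone, whether a carboxylic acid or a morpholine on the same carbonyl carbon would give a step beyond the scatter remains open. Going by these compounds, the response of compound 1 and compound 3 at other concentrations also remains open.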